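This account rests on a few compounds, and the source may have more. Where it says the series, first, only, none or still open, it means among the compounds named here.

Measured compounds:

Compound 1, `CS(=O)(=O)c1ccc(C(=O)NCCCC(=O)N2Cc3ccccc3C2)cc1[N+](=O)[O-]`. In an assay on isolated protein for inhibition of thyroid hormone receptor alpha (Homo sapiens), read by fluorescence polarization (on this read-out lower numbers stand for stronger inhibition and higher numbers for weaker inhibition), compound 1 gives > 60000 nM, which is a limit of the assay rather than a number.

Compound 2, `CS(=O)(=O)c1ccc(C(=O)NCCCC(=O)N2CCC(c3ccccc3)CC2)cc1[N+](=O)[O-]`. In this assay compound 2 gives > 60000 nM, again only a limit.

Compound 3, `CS(=O)(=O)c1ccc(C(=O)NCCCC(=O)N2CCCCC2)cc1[N+](=O)[O-]`. In this assay compound 3 gives > 60000 nM, once more a limit.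

All three compounds share the same core and differ only in the ring attached to the carbonyl carbon at the end of the chain. None of them reached a measurable number: every value stands at the limit of > 60000 nM in this assay, at which 3 of the 3 values shown sit, so compound 3 cannot be placed above or below its two companions. The step that the two limits leave unreadable from compound 1 to compound 3 and the step that the two limits leave unreadable from compound 2 to compound 3 therefore carry no readable size; they only show that swapping the ring at the carbonyl carbon, or removing a phenyl from it, did not bring inhibition into the measurable window.

Compound 4, `CC1CCN(C(=O)CCCNC(=O)c2ccc(S(C)(=O)=O)c([N+](=O)[O-])c2)CC1`, has not yet been measured. Compared with compound 3 it carries methyl in place of hydrogen on a saturated ring carbon. This change is small, and the two measured steps around compound 3 give no direction at all, so no movement beyond the scatter is expected, and the step that the limit leaves unreadable from compound 3 to compound 4 is estimated to leave the value at the limit. For compound 4 in this assay the expected value is 90000 nM, within a range from 30000 nM to 300000 nM.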

Compound 4, half-maximal inhibitory concentration: > 60000 nM
Compound 4: only a limit was reported; the forecaster's own chance of this, stated with the estimate: 90%; the middle value is on the limit's open side.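

Compound 4 also gives only a limit of the assay, so its steps from compound 1, compound 2 and compound 3 cannot be read, and none has a size: the limit of > 60000 nM in this assay, at which 4 of the 4 values shown sit.

The compounds shown leave open whether any group on the carbonyl carbon of the shared core can bring inhibition in this assay to a measurable number.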